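Moving the chlorine around the ring: compound 1 to compound 4

A few compounds are considered here, and "the series" means these few. Any claim that something is new, unique, unknown or untested is made for them only; others in the source may bear on it.

Measured so far:
- compound 1 `Cc1cc(NC(=O)Cn2cc(-c3ccc(Cl)cc3)nn2)no1`: 1910 nM
- compound 2 `C#Cc1ccc(-c2cn(CC(=O)Nc3cc(C)on3)nn2)cc1`: > 30000 nM
- compound 3 `Cc1csc(NC(=O)Cn2cc(-c3ccc(Cl)cc3)nn2)n1`: 520 nM

In a functional assay on BMDM cells (Mus musculus, strain C57BL/6) for inhibition, with a stated time of 2 days (a lower number here means a stronger inhibitor, a higher number a weaker inhibitor), compound 1 gives 1910 nM, the highest of the two numbers recorded; its nearest neighbour is compound 3, reached by a 3.7-fold lower number from compound 1 to compound 3 (0.57 log units; beyond the scatter). For compound 2 the assay reports only a limit, (the limit of > 30000 nM in this assay, at which 1 of the 3 values shown sits), and no number. The step to compound 2 is an at least 15-fold higher number from compound 1 to compound 2 (1.19 log units; beyond the scatter), showing that changing the group on this aromatic carbon can cost a great deal.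

Compound 4 `Cc1cc(NC(=O)Cn2cc(-c3cccc(Cl)c3)nn2)no1` keeps every atom of compound 1 but joins them differently: 3-chlorophenyl in place of 4-chlorophenyl on an aromatic carbon. Neither measured step tests where the chlorine sits, so the two only frame the question: a swap at this aromatic carbon was large and harmful, a swap at the amide-type nitrogen modest and helpful. With the chlorine merely shifted rather than exchanged, a smaller change than the step to compound 2 is expected, most likely a loss, so compound 4 is estimated at 4500 nM (range 1200 nM to 20000 nM), a step of a 2.4-fold higher number from compound 1 to compound 4 (0.37 log units; beyond the scatter).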

Compound 4, half-maximal inhibitory concentration: > 30000 nM
Compound 4: a limit, no number (the forecaster's own chance of this, stated with the estimate: 20%); middle value at least 6.6-fold (0.82 log units) from the limit.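

Shifting the chlorine alone, with no atom gained or lost, gives a step of an at least 15-fold higher number from compound 1 to compound 4 (1.19 log units; beyond the scatter). In this assay, then, the outcome depends not only on which group the phenyl ring carries but also on where the chlorine stands on that ring, something compound 2 could not show, as its chlorine was exchanged rather than moved. Compound 4, like compound 2, gives only a limit and no number, so the full size of the loss and any order between these two compounds cannot be read: the limit of > 30000 nM in this assay, at which 2 of the 4 values shown sit.

From the compounds shown here alone, what a bromine or a methoxy group would do in place of the chlorine of 4-chlorophenyl remains open. So does whether 3-chlorophenyl would cost as much when combined with the 4-methyl-1,3-thiazol-2-yl group of compound 3.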